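A few compounds are considered here, and "the series" means these few. Any claim that something is new, unique, unknown or untested is made for them only; others in the source may bear on it.

For the measured compounds named here, compound 2 `CC(C)(C)N(O)c1ccc(C(=O)NCc2ccccn2)cc1` is the weaker of the two compounds measured so far in a functional assay on the whole organism for inhibition, with Gerbillinae as the target; a lower number here means a stronger inhibitor, a higher number a weaker inhibitor. In this assay, going by the values given here, compound 2 gives 11100 nM, whereas compound 1 `CC(C)(C)N(O)c1ccc(C(=O)Nc2ccccn2)cc1` gives 4300 nM; the step of a 2.6-fold higher number from compound 1 to compound 2 (0.41 log units; beyond the scatter) is the only measured step in the set. Compound 3 `CC(C)(C)N(O)c1ccc(C(=O)Nc2nccs2)cc1` has not yet been measured. It differs from compound 2 in one place: 1,3-thiazol-2-yl in place of (pyridin-2-yl)methyl on an amide-type nitrogen. The measured step bears on this change only indirectly: going from compound 1 to compound 2 inserted a methylene between the amide-type nitrogen and the aromatic ring, and compound 3 again carries an aromatic ring attached directly to that nitrogen, as compound 1 does. On that basis the expectation is a step back downward in this assay, of roughly the size seen between compound 1 and compound 2, that is a 2.5-fold lower number from compound 2 to compound 3 (0.39 log units; beyond the scatter). Since the thiazol-2-yl ring is not the pyridin-2-yl ring of compound 1, the estimate is held wide. Compound 3 is therefore expected to give about 4500 nM in this assay, within a range from 1500 nM to 14000 nM.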

Compound 3, half-maximal inhibitory concentration: 1440 nM
Beside the measured number, compound 3's estimate is 3.1-fold (0.49 log units) above it; measured number outside the range, below it.
By their numbers in this assay, from the lowest: compound 3; then compound 1; then compound 2.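

With the attachment to the amide-type nitrogen held the same, the identity of the aromatic ring now proves to matter in this assay: the change from pyridin-2-yl to 1,3-thiazol-2-yl gives a 3.0-fold lower number from compound 1 to compound 3 (0.48 log units; beyond the scatter), whereas the earlier pair had varied only the methylene link and left the ring unchanged. Replacing (pyridin-2-yl)methyl with 1,3-thiazol-2-yl gives a 7.7-fold lower number from compound 2 to compound 3 (0.89 log units; beyond the scatter), but this single change alters both the link and the ring, so the compounds shown cannot divide the step between the two, and it leaves compound 3 as the strongest inhibitor of the three. Nothing available here explains why the five-membered ring with its two hetero atoms gives the lower number.

Going by these compounds, whether a methylene link would raise the number on the thiazole as it does on the pyridine remains open, and (1,3-thiazol-2-yl)methyl on the same nitrogen would test that directly. On these data alone, it is also open whether the sulfur atom or the ring size counts for more, a question that 1,3-oxazol-2-yl or a plain phenyl ring would help to separate.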